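The source may hold more compounds than are shown below. What is called first, only, known or untested is meant among the compounds shown, and "the series" means these compounds.

Three closely related compounds have been tested in a functional assay on OVCAR-5 cells (Homo sapiens) for cytotoxicity, read by sulforhodamine B assay, with a stated time of 48 h; a lower number here means that less compound is tolerated, a higher number that more compound is tolerated. Compound 3 `ClCc1cccc(Cn2cnc3nc(Cl)nc(Cl)c32)c1` gives 6300 nM. Compound 2 `ClCc1ccc(Cn2cnc3nc(Cl)nc(Cl)c32)cc1` has the same atoms joined differently; the difference between the two cores is not broken down here. In this assay compound 2 gives 8310 nM, which sits within the scatter of compound 3, so no order can be read between the two.

Compound 1 `ClCc1cccc(Cn2cnc3ncnc(Cl)c32)c1` is the counterpart of compound 3 with hydrogen in place of chloro on an aromatic carbon. For compound 1 the result in this assay is a limit rather than a number, > 100000 nM. It is a case of the limit of > 100000 nM in this assay, at which 1 of the 3 values shown sits. Accordingly, the change brings an at least 15-fold higher number from compound 3 to compound 1 (1.20 log units; beyond the scatter).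

Compound 4 `ClCc1ccc(Cn2cnc3ncnc(Cl)c32)cc1` has not yet been measured. It stands to compound 2 exactly as compound 1 stands to compound 3, carrying hydrogen in place of chloro on an aromatic carbon at a place described in the same words for both pairs, so it is the same change. Among the measured compounds shown here, its effect on compound 4 is an expectation only, resting on the one measured pair. The step expected is a 14-fold higher number from compound 2 to compound 4 (1.16 log units; beyond the scatter), drawn directly from the measured at least 15-fold higher number from compound 3 to compound 1 (1.20 log units; beyond the scatter). Compound 4 is therefore estimated at 120000 nM, with a range from 40000 nM to 400000 nM, and there is a fair chance that this assay will again report only a limit for compound 4.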

Compound 4, concentration lethal to 50% of the cells: 45700 nM
Beside the measured number, compound 4's estimate is 2.6-fold (0.42 log units) above it; the range from low to high includes it.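

In this assay, hydrogen in place of chloro on the aromatic carbon between two ring nitrogen atoms again moves the number the same way on the second core, giving a 5.5-fold higher number from compound 2 to compound 4 (0.74 log units; beyond the scatter), but the size of the step does not carry over unchanged: the same change on two cores in this assay, an at least 15-fold higher number (1.20 log units; beyond the scatter) from compound 3 to compound 1 and a 5.5-fold higher number (0.74 log units; beyond the scatter) from compound 2 to compound 4, at least 2.8-fold (0.46 log units) apart, beyond the scatter of two such steps. Going by these compounds, compound 1 is reported only as a limit, > 100000 nM, so the earlier step is known only as a lower bound, and the true gap between the two steps stays unknown. The two pairs show that the direction held across these two cores and that the size cannot simply be transferred from one to the other, but they do not show why the cores differ or how the change would behave on any further core.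

On these data alone, only chloro and hydrogen appear at that aromatic carbon, so what an amine or a methoxy group would do there remains open. Every compound shown also carries the chloromethyl group, which leaves open how these values would look with a hydroxymethyl or a plain methyl group in its place.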